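A few compounds are considered here, and "the series" means these few. Any claim that something is new, unique, unknown or untested is made for them only; others in the source may bear on it.

Of the compounds shown here, two have been measured so far in an assay on a protein complex for inhibition of CDK8/Cyclin C (Homo sapiens), with a stated time of 1 h, tested at 10 uM; a lower number here means less inhibition, a higher number more inhibition at the concentration tested (going by the name of the read-out). Compound 1, `NNC(=O)CCc1ccncc1-c1ccc2ccccc2c1`, gives 102% and so stands highest of the two numbers; compound 2, `NNC(=O)COc1ccncc1-c1ccc2ccccc2c1`, gives 19%. Going by the values given here, the one step between them, a number 83 percentage points lower from compound 1 to compound 2 (beyond the scatter), is large and lies beyond the scatter.

Compound 3, `O=C(CCc1ccncc1-c1ccc2ccccc2c1)N1CCOCC1`, has not yet been measured. It differs from compound 1 in one place: morpholin-4-yl in place of aminoamino on a carbonyl carbon. The change swaps a hydrazide end for a morpholine amide while keeping the rest of compound 1 untouched.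

Among the compounds with values here, no measured step bears on this change. Within the data shown here, the only known step, from compound 1 to compound 2, alters the chain between the ring and the carbonyl, not the group on the carbonyl carbon, so it gives no guide to what replacing aminoamino with morpholin-4-yl will do. The hydrogen-bond donors counted above are lost, and the outcome could range from a small to a large drop. Compound 3 is therefore expected to come in somewhat lower, the step of a number 42 percentage points lower from compound 1 to compound 3 (beyond the scatter) being an estimate with wide uncertainty, and its expected value is 60% with a range from 15% to 100%.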

Compound 3, a percentage reported as inhibition, at one concentration (the size of the read-out at that concentration, not a potency): 100%
Beside the measured number, compound 3's estimate is 40 percentage points below it; the measured number falls inside the stated range.
By their numbers in this assay, from the lowest: compound 2; then compounds 3 and 1 (each within the scatter of the next).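

In this assay, the step of a number 2 percentage points lower from compound 1 to compound 3 (within the scatter) shows that, on this carbonyl carbon next to a saturated chain carbon, morpholin-4-yl can stand in place of aminoamino with no change beyond the scatter. The entering group is larger, brings a six-membered non-aromatic ring and carries 0 hydrogen-bond donors against the 2 of the group that leaves, so in this pair neither those donors nor the smaller size is needed to keep the read-out at the concentration tested. Nothing measured on these compounds explains why the read-out holds across this change.

This read-out gives the size of the inhibition at one concentration and not a potency, so a real difference in potency between compound 1 and compound 3 could remain hidden. Also open, from the compounds shown here alone, are whether other groups on this carbonyl carbon, such as a hydroxyl giving a carboxylic acid or a piperidine ring with no ring oxygen, would behave the same way, and whether morpholin-4-yl would hold up on the chain of compound 2.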